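Methyl to Methoxy: the Same Small Change Made Twice

The source may report more compounds than this note shows. Statements on the series, on what has been measured and on what is new or still open speak of the compounds shown alone.

Compounds measured so far:
- compound 1 `Cc1ccc(OS(=O)(=O)c2ccc(N3CCN(C)C3=O)cc2)cc1` gives > 100000 nM in a functional assay on MCF7 cells (Homo sapiens) for antiproliferative activity, read by sulforhodamine B assay, with a stated time of 48 h; a lower number here means a stronger inhibitor, a higher number a weaker inhibitor
- compound 2 `COc1ccc(OS(=O)(=O)c2ccc(N3CCN(C)C3=O)cc2)cc1` gives 95000 nM in this assay
- compound 3 `CCCN1CCN(c2ccc(S(=O)(=O)Oc3cccc(C)c3)cc2)C1=O` gives 86000 nM in this assay

The value of compound 1 is a limit of this assay rather than a number (the limit of > 100000 nM in this assay, at which 1 of the 3 values shown sits). Compound 2 carries the change (methoxy in place of methyl on an aromatic carbon), and the step of an at least 1.0-fold lower number from compound 1 to compound 2 (0.02 log units; that floor lies within the scatter) is therefore only a floor, and one that lies within the scatter. Compound 3 belongs to a different core; how the core of compound 3 differs from that of compound 1 is not broken down here. The values of compound 2 and compound 3 lie within the scatter of each other, so no order between them can be read.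

Compound 4 `CCCN1CCN(c2ccc(S(=O)(=O)Oc3cccc(OC)c3)cc2)C1=O` is not yet measured. It differs from compound 3 by methoxy in place of methyl on an aromatic carbon. Within the data shown here, this is the same kind of change as the one from compound 1 to compound 2, but not the same: there the methoxy stands para to a large group, here it stands meta to a large group. Because the measured step of an at least 1.0-fold lower number from compound 1 to compound 2 (0.02 log units; that floor lies within the scatter) gives no more than a floor within the scatter, the step from compound 3 to compound 4 is expected to be small, about a 1.1-fold lower number from compound 3 to compound 4 (0.03 log units; within the scatter). The value of compound 4 in this assay is estimated at 80000 nM, between 35000 nM and 200000 nM, with a fair chance that only a limit is reported.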

Compound 4, half-maximal inhibitory concentration: 6300 nM
Beside the measured number, compound 4's estimate is 13-fold (1.10 log units) above it; measured number below the stated range.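

In this assay, putting methoxy in place of methyl on the core of compound 3 has a clear effect, with a 14-fold lower number from compound 3 to compound 4 (1.14 log units; beyond the scatter), so on this core the change matters far more than its small size might suggest. Compound 1 gives > 100000 nM, which is a limit of the assay and not a number, so the step that starts from it can be read only as a floor. Set side by side, the two steps therefore show neither that the large effect carries over from one core to the other nor that it stays confined to the core of compound 3: the same change on two cores in this assay, an at least 1.0-fold lower number (0.02 log units; that floor lies within the scatter) from compound 1 to compound 2 and a 14-fold lower number (1.14 log units; beyond the scatter) from compound 3 to compound 4; the limit leaves it open whether they differ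

The compounds shown leave open whether the large step would also appear with a 3-methoxyphenyl group on the core of compound 1, a pairing that would help separate the effect of the core from that of the place on the ring. They also leave open whether the methoxy itself is needed, or whether an ethoxy, a hydroxyl, an amine or a carboxylic acid at that ring carbon, or a longer chain on the core, would give a similar number.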